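Extending the chain once more on a histamine receptor ligand

The source may report more compounds than this note shows. Statements on the series, on what has been measured and on what is new or still open speak of the compounds shown alone.

Compound 1, `NCCCCCCc1c[nH]cn1`, is a simple imidazole carrying a saturated chain that ends in an amine. In an assay on CHO cells for displacement of a labelled ligand from histamine H2 receptor (Homo sapiens) (on this read-out higher numbers stand for weaker inhibition and lower numbers for stronger inhibition), compound 1 gives 200000 nM. Compound 2, `NCCCCCCCCc1c[nH]cn1`, keeps the same core and the same end group but has a longer chain. In this assay compound 2 gives 31600 nM. Among the compounds with values here, the only measured step so far is a 6.3-fold lower number from compound 1 to compound 2 (0.80 log units; beyond the scatter), and it places compound 2 at the lower, stronger end of the two numbers, clearly apart from compound 1.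

Compound 3, `NCCCCCCCCCCc1c[nH]cn1`, repeats the same kind of change: 2-aminoethyl in place of amino on a saturated chain carbon, eight bonds along the chain from an aromatic carbon. Within the data shown here, the one measured step that bears on it is the one from compound 1 to compound 2, which was of modest size and pointed toward stronger binding. Whether a further extension continues in the same direction is not known from these two compounds alone, so a smaller step is expected. The expected step is a 2.6-fold lower number from compound 2 to compound 3 (0.42 log units; beyond the scatter). Compound 3 is therefore estimated at 12000 nM, within a range from 3000 nM to 50000 nM.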

Compound 3, inhibition constant: 20000 nM
Estimate against measurement, compound 3: 1.7-fold (0.22 log units) below, and the stated range covers the measured number.
By their numbers in this assay, from the lowest: compounds 3 and 2 (each within the scatter of the next); then compound 1.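

Putting 2-aminoethyl in place of amino on a saturated chain carbon, eight bonds along the chain from an aromatic carbon, gives in this assay (a 1.6-fold lower number from compound 2 to compound 3 (0.20 log units; within the scatter)), so this second extension, unlike the first, cannot be told apart from the usual scatter of repeated measurements. The longer view still shows a real difference: with 4-aminobutyl in place of amino on a saturated chain carbon, six bonds along the chain from an aromatic carbon, the result is (a 10-fold lower number from compound 1 to compound 3 (1.00 log units; beyond the scatter)), which places compound 2 and compound 3 together and clearly apart from compound 1. Within the data shown here, the data on hand offer no explanation for why the first extension gives a step beyond the scatter and the second does not.

The compounds shown leave open whether a longer chain on the same core would stay level with compound 2 and compound 3, move clearly away from them, or reverse the trend. They also leave open how much of the binding depends on the amine at the chain end, which a carboxylic acid or an amide in its place would test.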